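Oxime in place of the aryl imine on the shared core

A few compounds are considered here, and "the series" means these few. Any claim that something is new, unique, unknown or untested is made for them only; others in the source may bear on it.

Measured so far:
compound 1 `Cc1ccc2[nH]c(=O)c(/C=N/c3ccc(C(=O)O)cc3)cc2c1` — 222000 nM
compound 2 `O=c1[nH]c2ccccc2cc1/C=N/c1ccccc1O` — 11700 nM
compound 3 `Cc1ccc2[nH]c(=O)c(/C=N/c3ccccc3O)cc2c1` — 8240 nM

In a functional assay, read by spectrophotometry, with a stated time of 3 min (on this read-out lower numbers stand for stronger inhibition and higher numbers for weaker inhibition), compound 3 gives the lowest of the three numbers. Its nearest neighbour is compound 2, and the step of a 1.4-fold lower number from compound 2 to compound 3 (0.15 log units; within the scatter) is within the scatter, so the two are not distinguished. Compound 1 is far away: compared with compound 3 its number is higher by a margin well beyond the scatter, and the two differ in the group on the double-bonded nitrogen, which suggests that this group drives the spread seen so far.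

Compound 4 `Cc1ccc2[nH]c(=O)c(/C=N/O)cc2c1` changes that position: hydroxy in place of 2-hydroxyphenyl on a double-bonded nitrogen. For the measured compounds named here, no measured step covers this change; the only measured step, from compound 2 to compound 3, concerns a methyl on the core and is within the scatter, so it gives no guidance. The comparison of compound 1 with compound 3 shows only that the nitrogen substituent matters greatly in this assay, not in which direction a hydroxy would go. Removing the whole aryl is expected to cost activity, so the step of a 6.1-fold higher number from compound 3 to compound 4 (0.78 log units; beyond the scatter) is estimated as a weakening. Compound 4 is expected to give about 50000 nM in this assay, within a range of 10000 nM to 250000 nM.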

Compound 4, half-maximal inhibitory concentration: 38900 nM
For compound 4 the middle estimate is 1.3-fold (0.11 log units) above the measured one; low and high end bracket the measured number.
By their numbers in this assay, from the lowest: compounds 3 and 2 (each within the scatter of the next); then compound 4; then compound 1.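

In this assay, for the compounds shown here, hydroxy in place of 2-hydroxyphenyl on a double-bonded nitrogen gives a 4.7-fold higher number from compound 3 to compound 4 (0.67 log units; beyond the scatter), the first measured step at this position: the ring is not needed for a measurable number, but removing it gives up some inhibition. The change leaves the counts of hydrogen-bond donors and acceptors and the net charge as they were, and takes away only the ring and its carbon atoms. Compound 1 stands at 222000 nM and compound 4 at 38900 nM, so an aryl group on this nitrogen does not by itself give the lower number.

Still open, from the compounds shown here alone, is how an amine or a methoxy group in place of this hydroxy would read. Going by these compounds, the methyl on the core has been read only with 2-hydroxyphenyl on the nitrogen, through a 1.4-fold lower number from compound 2 to compound 3 (0.15 log units; within the scatter), so its effect alongside hydroxy remains unknown. No available evidence bears on the reason for the new step.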